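Second Chloro on the Core: Expected Cytotoxicity of Compound 3

The source may hold more compounds than are shown below. What is called first, only, known or untested is meant among the compounds shown, and "the series" means these compounds.

Measured compounds:
compound 1 `ClCc1ccccc1Cn1cnc2c(Cl)ncnc21`: 75900 nM
compound 2 `ClCc1cccc(Cn2cnc3c(Cl)ncnc32)c1`: 79400 nM

In a functional assay on A549 cells (Homo sapiens) for cytotoxicity, read by sulforhodamine B assay, with a stated time of 48 h (on this read-out lower numbers stand for higher toxicity in this test and higher numbers for lower toxicity in this test), compound 2 gives 79400 nM, the higher of the two numbers, yet compound 1 with 75900 nM sits within the scatter of it, so the two are not distinguished. Compound 3 `ClCc1cccc(Cn2cnc3c(Cl)nc(Cl)nc32)c1` differs from compound 2 by chloro in place of hydrogen on an aromatic carbon. Going by the values given here, no measured pair shows such a change, so its size is unknown. In this assay the expected step is a 1.3-fold lower number from compound 2 to compound 3 (0.12 log units; within the scatter), a shift not clearly beyond the scatter and slightly toward higher toxicity. Compound 3 is thus estimated at 60000 nM, within 22000 nM to 160000 nM.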

Compound 3, concentration lethal to 50% of the cells: 52500 nM
For compound 3 the middle estimate is 1.1-fold (0.06 log units) above the measured one; the measured number falls inside the stated range.
By their numbers in this assay, from the lowest: compounds 3, 1 and 2 (each within the scatter of the next).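

In this assay, going by these compounds alone, chloro in place of hydrogen on an aromatic carbon between two ring nitrogen atoms gives a 1.5-fold lower number from compound 2 to compound 3 (0.18 log units; within the scatter), the first reading of any change at this position. The step stays within the scatter, so compound 3 is not distinguished from compound 2. Nothing measured here offers an explanation for this step.

From the compounds shown here alone, whether an amine, a methoxy group or a longer chain at this position would move the number beyond the scatter remains open. So does the size of the same change on compound 1.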